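N-alkylation of the aryl sulfonamide in a TRPV1 antagonist series

The compounds below may be only part of what the source reports. "The series", "measured", "known", "first", "only" and "open" are said of these compounds alone.

Measured so far:
compound 1, `COc1cc(C(C)C(=O)NCc2ccc(C(F)(F)F)nc2N2CCC(C)CC2)ccc1NS(C)(=O)=O`: 0.8 nM
compound 2, `CCS(=O)(=O)Nc1ccc(C(C)C(=O)NCc2ccc(C(F)(F)F)nc2N2CCC(C)CC2)cc1F`: 4.4 nM

In an assay on cells for antagonist activity at transient receptor potential cation channel subfamily V member 1 (Homo sapiens), read by FLIPR and calcium flux, with a stated time of 15 min (a higher number here means a weaker inhibitor, a lower number a stronger inhibitor), compound 2 gives 4.4 nM, the higher of the two numbers; compound 1 gives 0.8 nM, a gap beyond the scatter, so compound 2 is the weaker inhibitor of the pair.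

Compound 3, `CCN(c1ccc(C(C)C(=O)NCc2ccc(C(F)(F)F)nc2N2CCC(C)CC2)cc1F)S(C)(=O)=O`, is not yet measured. It differs from compound 2 by ethyl(methylsulfonyl)amino in place of (ethylsulfonyl)amino on an aromatic carbon; the sulfonamide hydrogen is lost. Among the compounds with values here, no measured pair shows this change, so the step is open. The expectation is a clear rise in the number, a 6.8-fold higher number from compound 2 to compound 3 (0.83 log units; beyond the scatter), giving compound 3 an estimated 30 nM in this assay, within a range of 8 nM to 150 nM.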

Compound 3, inhibition constant: 22.7 nM
For compound 3 the middle estimate is 1.3-fold (0.12 log units) above the measured one; low and high end bracket the measured number.
By their numbers in this assay, from the lowest: compound 1; then compound 2; then compound 3.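

In this assay, ethyl(methylsulfonyl)amino in place of (ethylsulfonyl)amino, on the aromatic carbon ortho to a fluoro group, gives a 5.2-fold higher number from compound 2 to compound 3 (0.71 log units; beyond the scatter). The sulfonamide hydrogen is therefore not essential for inhibition at this position, since compound 3 still reads 22.7 nM, though its loss comes with a modest weakening. Nothing available accounts for the step. On these data alone, it remains open whether a methyl or propyl group on the sulfonamide nitrogen would read differently from ethyl, and whether a carboxylic acid on that chain would be tolerated.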